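The source may hold more compounds than are shown below. What is called first, only, known or untested is meant among the compounds shown, and "the series" means these compounds.

Measured in a functional assay on KB cells (Homo sapiens) for antiproliferative activity, read by sulforhodamine B assay, with a stated time of 3 days; a higher number here means that more compound is needed for the effect, a lower number that less compound is needed:
- compound 1 `CCC1=C(O)c2c(oc(-c3ccc(CC)cc3)cc2=O)C(CC)(CC)C1=O`: 21.9 uM
- compound 2 `CCCc1ccc(-c2cc(=O)c3c(o2)C(CC)(CC)C(=O)C(CC)=C3O)cc1`: > 53 uM, a limit of the assay
- compound 3 `CCC1=C(O)c2c(oc(-c3ccc(C(C)C)cc3)cc2=O)C(CC)(CC)C1=O`: 8.13 uM

Compound 3 has the lowest number of the three, at 8.13 uM. Compound 4 `CCCCc1ccc(-c2cc(=O)c3c(o2)C(CC)(CC)C(=O)C(CC)=C3O)cc1` carries butyl in place of isopropyl on an aromatic carbon. For the measured compounds named here, two measured steps bear on this change. Extending the straight chain gave an at least 2.4-fold higher number from compound 1 to compound 2 (0.38 log units; beyond the scatter), while isopropyl in place of propyl gave an at least 6.5-fold lower number from compound 2 to compound 3 (0.81 log units; beyond the scatter). Both steps rest on (the limit of > 53 uM in this assay, at which 1 of the 3 values shown sits). Butyl is the longer straight chain, so a clear move to a higher number is expected in this assay. The expected change is a 4.9-fold higher number from compound 3 to compound 4 (0.69 log units; beyond the scatter). For compound 4 the estimated value is 40 uM, with an expected range of 15 uM to 110 uM.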

Compound 4, concentration for half-maximal effect: 111 uM
Compound 4: the middle estimate sits 2.8-fold (0.44 log units) below what was measured, and the stated range ends below it.
By their numbers in this assay, from the lowest: compound 3; then compound 1; then compound 4.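

Butyl in place of isopropyl on an aromatic carbon gives a 14-fold higher number from compound 3 to compound 4 (1.14 log units; beyond the scatter) in this assay, and ethyl in place of hydrogen on the chain gives a 5.1-fold higher number from compound 1 to compound 4 (0.70 log units; beyond the scatter). Among the three groups with readable values, butyl, the longest straight chain, carries the highest number and branched isopropyl the lowest. The step from compound 2 to compound 4 cannot be read, as compound 2 gives a limit: the limit of > 53 uM in this assay, at which 1 of the 4 values shown sits.

Open, on these data alone, is where a tert-butyl group or a chain longer than butyl would fall at this place. As far as these compounds go, an amine or a carboxylic acid there is equally open.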